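Ether to ester: from compound 3 to compound 4

A few compounds are considered here, and "the series" means these few. Any claim that something is new, unique, unknown or untested is made for them only; others in the source may bear on it.

The series shares one core, seen in compound 1 (`CC(C)=CC[C@@H](OC(=O)CCO)C1=CC(=O)c2c(O)ccc(O)c2C1=O`), compound 2 (`CC(C)=CC[C@@H](OC[C@H](C)O)C1=CC(=O)c2c(O)ccc(O)c2C1=O`) and compound 3 (`COC(C)CO[C@H](CC=C(C)C)C1=CC(=O)c2c(O)ccc(O)c2C1=O`). In a functional assay on HeLa cells (Homo sapiens) for cytotoxicity, read by MTT assay (on this read-out lower numbers stand for stronger inhibition and higher numbers for weaker inhibition), compound 1 gives 67600 nM, compound 2 gives 40300 nM and compound 3 gives 53400 nM. Compound 3 stands within the scatter of both others: a 1.3-fold lower number from compound 1 to compound 3 (0.10 log units; within the scatter), and a 1.3-fold higher number from compound 2 to compound 3 (0.12 log units; within the scatter).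

The next compound is compound 4 (`CCCCC(O)CC(=O)O[C@H](CC=C(C)C)C1=CC(=O)c2c(O)ccc(O)c2C1=O`), with this change: (2-hydroxyhexyl)carbonyl in place of 2-methoxypropyl on an oxygen on a saturated carbon. Compound 1 is the closest measured guide, since it also carries a carbonyl-linked chain on that oxygen. Both measured exchanges at this oxygen stayed within the scatter: a 1.7-fold lower number from compound 1 to compound 2 (0.22 log units; within the scatter), and a 1.3-fold lower number from compound 1 to compound 3 (0.10 log units; within the scatter). For the measured compounds named here, no measured compound carries the (2-hydroxyhexyl)carbonyl chain, so the range stays wide. No step beyond the scatter is therefore expected in this assay, and the estimate is a 1.3-fold lower number from compound 3 to compound 4 (0.13 log units; within the scatter). Compound 4 is estimated at 40000 nM, with an expected range of 13000 nM to 90000 nM.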

Compound 4, half-maximal inhibitory concentration: 72200 nM
Estimate against measurement, compound 4: 1.8-fold (0.26 log units) below; the range from low to high includes it.
By their numbers in this assay, from the lowest: compounds 2, 3, 1 and 4 (each within the scatter of the next).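

For the compounds shown here, at the oxygen on a saturated carbon, this assay tolerates a larger exchange than the earlier compounds showed: replacing 2-methoxypropyl (5 heavy atoms) with (2-hydroxyhexyl)carbonyl (9 heavy atoms) gives a 1.4-fold higher number from compound 3 to compound 4 (0.13 log units; within the scatter) and leaves the number within the scatter. The comparison with the 2-hydroxypropyl ether gives a 1.8-fold higher number from compound 2 to compound 4 (0.25 log units; within the scatter) and also stays within the scatter, so neither ether separates from the new ester in this assay. Within the ester pair, adding butyl to the chain gives a 1.1-fold higher number from compound 1 to compound 4 (0.03 log units; within the scatter) and thus shows no measurable effect of this extension on the number. No available measurement accounts for these small steps.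

On these data alone, whether an amine or a carboxylic acid on this chain would produce a step beyond the scatter remains open. The same holds for a phenyl ring at this oxygen and for a hexanoyl chain without the hydroxyl.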